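The source may report more compounds than this note shows. Statements on the series, on what has been measured and on what is new or still open speak of the compounds shown alone.

Compound 1 `CCN(CC)Cc1cc(C)cc(Nc2nc3ccccc3n2Cc2ccc(F)cc2)c1O` carries a fluoro group on one of its aromatic rings, and in an ADME assay on CHO cells (Cricetulus griseus) for inhibition, read by MTT assay (a higher number here means a weaker inhibitor, a lower number a stronger inhibitor), compound 1 gives 18700 nM. Compound 2 `CCN(CC)Cc1cc(C)cc(Nc2nc3ccccc3n2Cc2ccc(C(F)(F)F)cc2)c1O` differs by one change, (trifluoromethyl in place of fluoro on an aromatic carbon), and in this assay compound 2 gives 29300 nM; the step of a 1.6-fold higher number from compound 1 to compound 2 (0.20 log units; within the scatter) is small. Compound 3 `CCN(CC)Cc1ccc(Nc2nc3ccccc3n2Cc2ccc(F)cc2)cc1O` shares the fluoro group but has a different core; how its core differs from that of compound 1 is not broken down here. In this assay compound 3 gives 45800 nM. Compound 4 `CCN(CC)Cc1ccc(Nc2nc3ccccc3n2Cc2ccc(C(F)(F)F)cc2)cc1O` is still unmeasured and differs from compound 3 by the same change, (trifluoromethyl in place of fluoro on an aromatic carbon), made at the same kind of place. The expected step is a 1.6-fold higher number from compound 3 to compound 4 (0.20 log units; within the scatter), resting on the earlier step of a 1.6-fold higher number from compound 1 to compound 2 (0.20 log units; within the scatter). Compound 4 is thus estimated to give 73000 nM, between 40000 nM and 135000 nM.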

Compound 4, half-maximal inhibitory concentration: 41500 nM
Compound 4: the middle estimate sits 1.8-fold (0.25 log units) above what was measured; the range from low to high includes it.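

In this assay, putting trifluoromethyl in place of fluoro on the second core gives a step that is small: a 1.1-fold lower number from compound 3 to compound 4 (0.04 log units; within the scatter). Set beside the same change on the first core, the two steps cannot be told apart: the same change on two cores in this assay, a 1.6-fold higher number (0.20 log units; within the scatter) from compound 1 to compound 2 and a 1.1-fold lower number (0.04 log units; within the scatter) from compound 3 to compound 4, 1.7-fold (0.24 log units) apart, within the scatter of two such steps. This shows that the change carries across these two cores as a step within the scatter, but it does not show that the change has a real effect on either core, and two pairs say nothing about cores beyond these.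

The compounds shown leave open whether a group without fluorine, such as an amine or a carboxylic acid, would give a larger step in place of the fluoro. They also leave open whether such a step would carry from one core to the other.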